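Extending the amide chain from butyl toward octyl

This account rests on a few compounds, and the source may have more. Where it says the series, first, only, none or still open, it means among the compounds named here.

Measured compounds:
- compound 1, `CCCCNC(=O)C1C(C(=O)O)[C@@H]2CC[C@H]1O2`: 10000 nM
- compound 2, `O=C(O)C1C(C(=O)NCC2Cc3ccsc3CO2)[C@H]2CC[C@@H]1O2`: 10000 nM

In an ADME assay on SW480 cells (Homo sapiens) for cytotoxicity, read by MTT assay, with a stated time of 72 h (a lower number here means a stronger inhibitor of growth, a higher number a weaker inhibitor of growth), compound 1 gives 10000 nM, level with compound 2 at the digits shown; the two lie within the scatter of each other. Compound 3, `CCCCCCCCNC(=O)C1C(C(=O)O)[C@@H]2CC[C@H]1O2`, is not yet measured. It differs from compound 1 by butyl in place of hydrogen on a saturated chain carbon, four bonds along the chain from an amide-type nitrogen. Among the compounds with values here, no measured pair shows a step of this kind, so there is no guide to its size. The step from compound 1 to compound 3 is expected to be no change at the digits printed from compound 1 to compound 3 (within the scatter), none beyond the scatter. Compound 3 is estimated at 10000 nM, within 3000 nM to 20000 nM.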

Compound 3, concentration for 50% growth inhibition: 10000 nM
Beside the measured number, compound 3's estimate shows no gap at the digits printed; measured number inside the range.
By their numbers in this assay, from the lowest: compounds 1, 2 and 3 (each within the scatter of the next).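

In this assay butyl placed on a saturated chain carbon, four bonds along the chain from an amide-type nitrogen, gives no change at the digits printed from compound 1 to compound 3 (within the scatter) for this lengthening of the amide chain. Within the data shown here, this is the first step read at this position, and it shows that going from the butyl chain to the octyl chain does not move the number. Nothing measured here offers an explanation for this result. Still open, on these data alone, is whether a chain longer than octyl, or a chain ending in an amine or a hydroxyl group, would change the number in this assay for this core.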